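The source may report more compounds than this note shows. Statements on the series, on what has been measured and on what is new or still open speak of the compounds shown alone.

Compound 1 `O=C(O)c1cncc(C2=C(c3cc(Cl)ccc3OCc3ccc(F)cc3F)CCC2)n1` is one of three compounds for which the result of an assay on isolated protein for inhibition of prostaglandin E2 receptor EP1 subtype (Homo sapiens) (a higher number here means a weaker inhibitor, a lower number a stronger inhibitor), is known. In this assay compound 1 gives 2 nM, the second highest of the three numbers. Compound 3 `Cc1ncc(C2=C(c3cc(Cl)ccc3OCc3ccc(F)cc3)CCC2)cc1C(=O)O` gives 1.59 nM, a number within the usual scatter of that of compound 1. Compound 2 `CSc1ccc(OCc2ccc(F)cc2F)c(C2=C(c3cccc(C(=O)O)c3)CCC2)c1` gives 15.9 nM, a higher number than that of compound 1, a gap beyond the scatter.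

Compound 4 `O=C(O)c1cnnc(C2=C(c3cc(Cl)ccc3OCc3ccc(F)cc3F)CCC2)c1` differs from compound 1 in one place: 5-carboxypyridazin-3-yl in place of 6-carboxypyrazin-2-yl on a double-bonded ring carbon. Going by the values given here, no pair of measured compounds shows this change, so its effect in this assay is not known. A step of only modest size is expected, from compound 1 to compound 4 a 1.5-fold higher number from compound 1 to compound 4 (0.18 log units; within the scatter), possibly none beyond the scatter. Compound 4 is therefore estimated to give 3 nM, expected to fall between 1 nM and 10 nM.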

Compound 4, half-maximal inhibitory concentration in the prostaglandin E2 receptor EP1 subtype assay: 6.31 nM
Compound 4: middle estimate off by 2.1-fold (0.32 log units), on the low side; the range from low to high includes it.
By their numbers in the prostaglandin E2 receptor EP1 subtype assay, from the lowest: compounds 3 and 1 (each within the scatter of the next); then compound 4; then compound 2.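

In the prostaglandin E2 receptor EP1 subtype assay, this position is sensitive to the exact ring: 5-carboxypyridazin-3-yl in place of 6-carboxypyrazin-2-yl gives a 3.2-fold higher number from compound 1 to compound 4 (0.50 log units; beyond the scatter), although the two groups have the same atoms. What matters here is therefore how those atoms are joined, not only which atoms are present. In a physicochemical assay for lipophilicity (a lower number here means a more polar compound, a higher number a more lipophilic compound), compound 1 gives 1.6 and compound 4 gives 1.2. The same change also gives a more polar compound in the physicochemical assay: the measured distribution coefficient of compound 1, 1.6, and of compound 4, 1.2, a number 0.40 log units lower (beyond the scatter)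

This single pair cannot tell whether that shift accounts for the weaker binding in the prostaglandin E2 receptor EP1 subtype assay. It also leaves open how a tetrazole or an amide in place of the carboxylic acid would fare on either ring.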